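This account rests on a few compounds, and the source may have more. Where it says the series, first, only, none or still open, it means among the compounds named here.

The starting point here is compound 2 `CCOc1cc(Cl)c(-c2ccnc3c2nc(C)c(=O)n3C(CC)C2CC2)cc1C`. In a functional assay for antagonist activity at corticotropin-releasing factor receptor 1 (Rattus norvegicus) (a lower number here means a stronger inhibitor, a higher number a weaker inhibitor), compound 2 gives 2 nM. For the measured compounds named here, the other compound measured so far is compound 1 `COCC(C1CC1)n1c(=O)c(C)nc2c(-c3cc(F)c(OC)cc3Cl)ncnc21`, which in this assay gives 7.5 nM. Compound 2 therefore has the lower of the two numbers, and its gap to compound 1 lies beyond the ordinary scatter of repeated measurements. The two compounds differ from each other in more than one place, so this gap cannot be tied to any single change. The step followed now leads to compound 3 `CCC(C1CC1)n1c(=O)c(C)nc2c(-c3cc(C)c(OC(C)C)cc3Cl)ccnc21`, which has not yet been measured. It differs from compound 2 in one place only: methyl in place of hydrogen on a saturated chain carbon bound to an oxygen on an aromatic ring and a saturated chain carbon. Going by the values given here, no measured pair with a single change of this kind exists here, so there is no direct guide to the size of the step. A change this small would be expected to leave the number in this assay close to where compound 2 stands, with any shift most likely inside the scatter. Compound 3 is therefore estimated at 2 nM, within a range from 0.8 nM to 6 nM, an expected step of no change at the digits printed from compound 2 to compound 3 (within the scatter).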

Compound 3, half-maximal inhibitory concentration: 15 nM
Beside the measured number, compound 3's estimate is 7.5-fold (0.88 log units) below it, outside the stated range (above it).
By their numbers in this assay, from the lowest: compound 2; then compounds 1 and 3 (each within the scatter of the next).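

In this assay, the change from ethoxy to isopropoxy gives a 7.5-fold higher number from compound 2 to compound 3 (0.88 log units; beyond the scatter), so a single methyl added on the saturated chain carbon bound to the oxygen is enough to weaken inhibition beyond the usual scatter. For the compounds shown here, this is the first comparison here that isolates one change, and it shows that this position is not indifferent to a small addition of just one carbon: within this pair, ethoxy is the better of the two groups. No measurement shown here accounts for the rise in the number, so the result records what happened without explaining it.

The compounds shown leave open how this position responds to other groups, since one pair gives only a single step and cannot show a trend. A straight-chain propoxy group, which adds a carbon further out rather than on the chain carbon bound to the oxygen, or a larger tert-butoxy group, each on the otherwise unchanged structure of compound 2, would show whether the number depends on the size of the group or on branching at that carbon.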